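The source may hold more compounds than are shown below. What is called first, only, known or untested is meant among the compounds shown, and "the series" means these compounds.

The study compares three compounds that share one core. Compound 1 `CC(C)C(Cc1ncc[nH]1)c1ccc(-c2ccc3cccc(F)c3c2)[nH]c1=O` carries a (1H-imidazol-2-yl)methyl group on a saturated chain carbon bound to an aromatic carbon and a saturated chain carbon. In an ADME assay on microsomes from liver (Rattus norvegicus) for metabolic stability (a higher number here means that the compound lasts longer, a lower number that the compound disappears faster), compound 1 gives < 0.0667 h, and that figure is a limit of the assay rather than a measured number. Where compound 1 stands can thus only be said in one way: it sits at the limit of < 0.0667 h in this assay, at which 1 of the 2 values shown sits. Going by the values given here, compound 2 `CC(C)[C@H](C[C@H]1CCNC1=O)c1ccc(-c2ccc3cccc(F)c3c2)[nH]c1=O` differs from compound 1 in more than one place, so no single step joins them; in this assay compound 2 gives 0.227 h, a number rather than a limit. Compound 3 `CC(C)C(c1ncc[nH]1)c1ccc(-c2ccc3cccc(F)c3c2)[nH]c1=O` has not yet been measured in this assay. It differs from compound 1 by 1H-imidazol-2-yl in place of (1H-imidazol-2-yl)methyl on a saturated chain carbon bound to an aromatic carbon and a saturated chain carbon. Among the compounds with values here, with compound 1 offering only a limit, no measured step shows what this change does to the half-life. The step of an at least 1.0-fold higher number from compound 1 to compound 3 (0.02 log units; that floor lies within the scatter) is expected to stay within the usual scatter, in no clear direction. Compound 3 is therefore estimated at 0.07 h, between 0.03 h and 0.2 h, with a real chance that this assay again reports only a limit.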

Compound 3, half-life: < 0.0667 h
Compound 3: no number, only a limit (the forecaster's own chance of this, stated with the estimate: 55%); middle value at least 1.0-fold (0.02 log units) away from the limit.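

In this assay compound 3 gives < 0.0667 h, which is a limit of the assay and not a number. Going by these compounds alone, no step from compound 1 to compound 3 can be read, because both compounds sit at a limit: the limit of < 0.0667 h in this assay, at which 2 of the 3 values shown sit. The compounds shown leave open whether 1H-imidazol-2-yl in place of (1H-imidazol-2-yl)methyl changes the half-life at all, and in which direction.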